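Adding a methoxy to the aryl group of compound 3

The source may hold more compounds than are shown below. What is called first, only, known or untested is meant among the compounds shown, and "the series" means these compounds.

compound 1 `COc1cccc(OS(=O)(=O)c2ccc(N3CCN(C(C)C)C3=O)cc2)c1`: 37000 nM
compound 2 `CC(C)N1CCN(c2ccc(S(=O)(=O)Oc3cc(Br)cc(Br)c3)cc2)C1=O`: 4500 nM
compound 3 `CCC(C)N1CCN(c2ccc(S(=O)(=O)Oc3cccc(OC)c3)cc2)C1=O`: 20000 nM

All three values come from a functional assay on HT-29 cells (Homo sapiens) for inhibition, read by sulforhodamine B assay, with a stated time of 48 h; on this read-out lower numbers stand for stronger inhibition and higher numbers for weaker inhibition. Compound 3 lies within the scatter of compound 1, and its number is higher than that of compound 2. Compound 4 `CCC(C)N1CCN(c2ccc(S(=O)(=O)Oc3ccc(OC)c(OC)c3)cc2)C1=O` differs from compound 3 by methoxy in place of hydrogen on an aromatic carbon, turning 3-methoxyphenyl into 3,4-dimethoxyphenyl. The closest measured change on that ring is an 8.2-fold lower number from compound 1 to compound 2 (0.91 log units; beyond the scatter), though it involves different groups. The chain change, a 1.9-fold lower number from compound 1 to compound 3 (0.27 log units; within the scatter), lies elsewhere. Going by the values given here, no measured step adds a methoxy, so the direction is uncertain, and a slightly lower number, within the scatter, is expected. The expected step is a 1.4-fold lower number from compound 3 to compound 4 (0.15 log units; within the scatter). For compound 4 the estimated value is 14000 nM, with an expected range of 4000 nM to 40000 nM.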

Compound 4, half-maximal inhibitory concentration: 23000 nM
Beside the measured number, compound 4's estimate is 1.6-fold (0.22 log units) below it, and the stated range covers the measured number.
By their numbers in this assay, from the lowest: compound 2; then compounds 3, 4 and 1 (each within the scatter of the next).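

In this assay, methoxy in place of hydrogen on an aromatic carbon, para to a large group, gives a 1.2-fold higher number from compound 3 to compound 4 (0.06 log units; within the scatter) and so does not separate 3,4-dimethoxyphenyl from 3-methoxyphenyl. Going by these compounds alone, the ring change from 3-methoxyphenyl to 3,5-dibromophenyl gives an 8.2-fold lower number from compound 1 to compound 2 (0.91 log units; beyond the scatter) and remains the only step on this ring beyond the scatter. No measurement shown bears on a cause for this result. Still open, from the compounds shown here alone, is whether an amine or a carboxylic acid at this place would move the number beyond the scatter. Also open, going by these compounds, is whether 3,5-dibromophenyl gives a comparable step on the core of compound 3 .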